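The source may hold more compounds than are shown below. What is called first, only, known or untested is meant among the compounds shown, and "the series" means these compounds.

Working notes on the series. Three compounds carry numbers in a functional assay on HepG2 cells (Homo sapiens) for cytotoxicity, read by MTT assay, with a stated time of 72 h; on this read-out higher numbers stand for weaker inhibition and lower numbers for stronger inhibition. Compound 1 `Cn1ccc2c(Oc3ccc(NC(=O)c4nn(-c5ccc(Br)cc5)ccc4=O)cc3)ccnc21` gives 39200 nM in this assay. Compound 2 `Cc1cc(=O)n(-c2ccccc2OC(F)(F)F)nc1C(=O)Nc1ccc(Oc2ncnc3[nH]ccc23)cc1` gives 22800 nM in this assay. Compound 3 `Cc1cc(=O)n(-c2ccccc2OC(F)(F)F)nc1C(=O)Nc1ccc(Oc2ncnc3c2ccn3C)cc1` gives > 60000 nM in this assay, which is a limit of the assay and not a number. The only step measured in one place is an at least 2.6-fold higher number from compound 2 to compound 3 (0.42 log units; beyond the scatter); compound 3 therefore stands at the weak end of what is shown, its value being the limit described by the limit of > 60000 nM in this assay, at which 1 of the 3 values shown sits.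

Compound 4 `Cc1cc(=O)n(-c2ccccc2C(F)(F)F)nc1C(=O)Nc1ccc(Oc2ncnc3c2ccn3C)cc1` is not yet measured. It differs from compound 3 by trifluoromethyl in place of trifluoromethoxy on an aromatic carbon. None of the measured steps bears on this change; the only step shown, from compound 2 to compound 3, concerns methyl in place of hydrogen on an aromatic nitrogen, and compound 1 shares neither the trifluoromethoxy group nor the core of compound 3. Since compound 3 gives only a limit in this assay, the change to compound 4 is expected to produce a number no higher from compound 3 to compound 4 (the limit leaves the size open), that is, nothing beyond the scatter. Compound 4 is therefore expected to give about 60000 nM in this assay, within the range 25000 nM to 150000 nM, with a real chance that only a limit is reported.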

Compound 4, half-maximal inhibitory concentration: 27200 nM
Compound 4: the middle estimate sits 2.2-fold (0.34 log units) above what was measured, within the range that was stated.
By their numbers in this assay, from the lowest: compounds 2, 4 and 1 (each within the scatter of the next). At a limit, above all of these: compound 3.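

In this assay, trifluoromethyl in place of trifluoromethoxy on the aromatic carbon ortho to a large group gives an at least 2.2-fold lower number from compound 3 to compound 4 (0.34 log units; beyond the scatter). For the compounds shown here, this is the first measured change at this position, since the only earlier step concerned methyl in place of hydrogen on an aromatic nitrogen; it shows that, on the methylated core shared by compound 3 and compound 4, the group on this aromatic carbon alone can move the read-out beyond the scatter, and that the loss of a number seen with compound 3 is not fixed by the methyl on the nitrogen alone. The step is a bound and not a measured size, as compound 3 gives only a limit of the assay: the limit of > 60000 nM in this assay, at which 1 of the 4 values shown sits.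

The compounds shown leave open whether the same change has a similar effect on the core of compound 2, which carries hydrogen on the aromatic nitrogen, and how large the step would be against a true number. They also leave open how a methoxy group, a chlorine atom, an amine or a carboxylic acid would read on the same aromatic carbon.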